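The compounds below may be only part of what the source reports. "The series", "measured", "known", "first", "only" and "open" are said of these compounds alone.

Measured compounds:
compound 1 `Clc1ccc(-c2cn3ccnc3c(-c3ccc4ncn(C5CCCCC5)c4c3)n2)cc1`, 11.6%
compound 2 `COc1ccccc1-c1cn2ccnc2c(-c2ccc3ncn(C4CCCCC4)c3c2)n1`, 13.9%
compound 3 `Fc1ccccc1-c1cn2ccnc2c(-c2ccc3ncn(C4CCCCC4)c3c2)n1`, 9.1%

All three were tested in a functional assay on A549 cells (Homo sapiens) for inhibition, read by sulforhodamine B assay, with a stated time of 48 h, tested at 10 uM; on this read-out lower numbers stand for less inhibition and higher numbers for more inhibition at the one concentration tested (going by the name of the read-out). Compound 3 gives the lowest of the three numbers, but its nearest neighbour, compound 1, differs by a number 2.5 percentage points lower from compound 1 to compound 3 (within the scatter) and the furthest, compound 2, by a number 4.8 percentage points lower from compound 2 to compound 3 (within the scatter), so the three sit together within the scatter. Compound 4 `c1csc(-c2cn3ccnc3c(-c3ccc4ncn(C5CCCCC5)c4c3)n2)c1` has not been measured; it differs from compound 3 by thiophen-2-yl in place of 2-fluorophenyl on an aromatic carbon. The two measured steps that also swap the group on that aromatic carbon lie within the scatter, so another swap there is expected to give no step beyond the scatter, a number 1.9 percentage points higher from compound 3 to compound 4 (within the scatter). Compound 4 is estimated at 11%, between 3% and 20%.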

Compound 4, a percentage reported as inhibition, at one concentration (the size of the read-out at that concentration, not a potency): 5.33%
For compound 4 the middle estimate is 5.7 percentage points above the measured one; the measured number falls inside the stated range.
By their numbers in this assay, from the lowest: compounds 4, 3, 1 and 2 (each within the scatter of the next).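

The thiophen-2-yl compound brings a change of ring type at this position: a five-membered aromatic ring with a sulfur atom replaces the six-membered carbon rings, yet in this assay all three new steps stay within the scatter (a number 3.8 percentage points lower from compound 3 to compound 4 (within the scatter); a number 8.6 percentage points lower from compound 2 to compound 4 (within the scatter); a number 6.3 percentage points lower from compound 1 to compound 4 (within the scatter)). No ring swapped in here has yet moved the number measurably, and no available evidence explains this. An amine, a carboxylic acid or a longer chain on this aromatic carbon remains untested among the compounds shown, so it stays open whether any group here can move the number beyond the scatter.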